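From Compound 1 to Compound 4 in a Chemokine Binding Series

This account rests on a few compounds, and the source may have more. Where it says the series, first, only, none or still open, it means among the compounds named here.

Compound 1 `Cc1ccc(C(=O)N[C@@H](C(=O)N2CCC(c3ccc(Cl)cc3)CC2)C(C)C)cc1` gives 25 nM in an assay on THP-1 cells for displacement of a labelled ligand from C-C chemokine receptor type 1 (Homo sapiens) (on this read-out lower numbers stand for stronger inhibition and higher numbers for weaker inhibition), the lowest of the three numbers recorded there. Compound 2 `CC[C@@H](NC(=O)c1ccccc1)C(=O)N1CCC(c2ccc(Cl)cc2)CC1` gives 121 nM, and compound 3 `CC(C)(C)C(NC(=O)c1ccccc1)C(=O)N1CCC(c2ccc(Cl)cc2)CC1` gives 259 nM; both gaps to compound 1 lie beyond the scatter, and each of these two compounds differs from compound 1 in more than one place. Compound 4 `CC(C)[C@@H](NC(=O)CCc1ccc(F)cc1)C(=O)N1CCC(c2ccc(Cl)cc2)CC1` has not yet been measured. It differs from compound 1 in one place: 2-(4-fluorophenyl)ethyl in place of 4-methylphenyl on a carbonyl carbon. For the measured compounds named here, no measured pair shows this change, so the expectation rests on compound 1 alone. A modest weakening, close to the edge of the scatter, is expected, giving the step of a 2.0-fold higher number from compound 1 to compound 4 (0.30 log units; within the scatter). Compound 4 is therefore estimated at 50 nM in this assay, within 15 nM to 170 nM.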

Compound 4, half-maximal inhibitory concentration: 70 nM
For compound 4 the middle estimate is 1.4-fold (0.15 log units) below the measured one; measured number inside the range.
By their numbers in this assay, from the lowest: compound 1; then compounds 4 and 2 (each within the scatter of the next); then compound 3.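

In this assay, placing 2-(4-fluorophenyl)ethyl instead of 4-methylphenyl on the carbonyl carbon gives a 2.8-fold higher number from compound 1 to compound 4 (0.45 log units; beyond the scatter). This position therefore accepts a larger group, with 9 heavy atoms rather than 7, at a modest cost, and inhibition stays measurable. Nothing available explains this step.

The step changes the chain and the fluorine together, and the compounds shown do not separate the two. Going by these compounds, how a plain 2-phenylethyl group, or a group carrying an amine or a carboxylic acid, would fare at this position remains open.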